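The compounds below may be only part of what the source reports. "The series", "measured", "known", "first", "only" and "open" are said of these compounds alone.

Measured so far:
- compound 1 `O=c1ccoc2cc(OCc3cn(Cc4ccccc4)nn3)ccc12`; in a functional assay on MDA-MB-231 cells (Homo sapiens) for cytotoxicity, read by MTT assay, with a stated time of 48 h (on this read-out higher numbers stand for weaker inhibition and lower numbers for stronger inhibition), compound 1 gives > 100000 nM, a limit of the assay.
- compound 2 `O=c1ccoc2cc(OCc3cn(Cc4ccc(Cl)cc4Cl)nn3)ccc12`; in this assay compound 2 gives > 100000 nM, again a limit.
- compound 3 `O=c1ccoc2cc(OCc3cn(Cc4ccc(F)cc4)nn3)ccc12`; in this assay compound 3 gives > 100000 nM, also a limit.

Compound 3 therefore stands only at a limit, as do the other two; all three sit at the limit of > 100000 nM in this assay, at which 3 of the 3 values shown sit. The steps a step that the two limits leave unreadable from compound 1 to compound 2, a step that the two limits leave unreadable from compound 1 to compound 3 and a step that the two limits leave unreadable from compound 2 to compound 3 are each unreadable, the two limits hiding any size or direction. Compound 4 `O=c1ccoc2cc(OCc3cn(Cc4ccc([N+](=O)[O-])cc4)nn3)ccc12` differs from compound 3 by nitro in place of fluoro on an aromatic carbon. Within the data shown here, no measured step bears readably on this change. The expectation is that compound 4 behaves like the rest, so a step that the limit leaves unreadable from compound 3 to compound 4 is expected to be none beyond the scatter, with the value most likely again a limit. Compound 4 is estimated at 150000 nM, in the range 50000 nM to 600000 nM.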

Compound 4, half-maximal inhibitory concentration: 71300 nM
The estimate for compound 4 lay 2.1-fold (0.32 log units) above the measured number, within the range that was stated.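

Nitro on an aromatic carbon para to a large group gives the first number in this assay that is not a limit, and the steps to it read an at least 1.4-fold lower number from compound 3 to compound 4 (0.14 log units; that floor lies within the scatter), an at least 1.4-fold lower number from compound 2 to compound 4 (0.14 log units; that floor lies within the scatter) and an at least 1.4-fold lower number from compound 1 to compound 4 (0.14 log units; that floor lies within the scatter). Each of these is only a floor lying within the scatter, so no real gain over the other three compounds is established. Those three stay unreadable against one another, and the limit still holds most of the series: the limit of > 100000 nM in this assay, at which 3 of the 4 values shown sit.

Going by these compounds, how far compound 1, compound 2 and compound 3 truly sit from compound 4 stays open. So does whether an amine or a carboxylic acid in place of nitro at this position, or a longer chain in place of the saturated chain carbon, would move the number.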